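Clearance notes ahead of the pyrazolyl amine

This account rests on a few compounds, and the source may have more. Where it says the series, first, only, none or still open, it means among the compounds named here.

In an ADME assay on microsomes from liver (Homo sapiens) for pharmacokinetics, read by LC-MS, using NADPH, with a stated time of 45 min, tested at 1 uM (on this read-out lower numbers stand for slow clearance and higher numbers for fast clearance), compound 3 `COc1cc(OCc2ccnc(N)n2)c(Cl)c2sc(N[C@H]3CCCC[C@@H]3O)nc12` gives 33 mL/min/kg, within the scatter of compound 1 `Nc1nccc(COc2cc(Cl)c3nc(N[C@@H]4CCCC[C@H]4O)sc3c2)c1Cl` at 32 mL/min/kg. Compound 2 `COc1cc(OCc2ccnc(N)n2)cc2sc(N[C@H]3CCCC[C@@H]3O)nc12` gives 9.5 mL/min/kg. Within the data shown here, the only measured step is a 3.5-fold higher number from compound 2 to compound 3 (0.54 log units; beyond the scatter), for chloro in place of hydrogen on an aromatic carbon, and it lies beyond the scatter.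

The next change leads to compound 4 `COc1cc(OCc2ccnc(Nc3cnn(C)c3)n2)c(Cl)c2sc(N[C@H]3CCCC[C@@H]3O)nc12`: 1-methyl-1H-pyrazol-4-yl in place of hydrogen on a nitrogen on an aromatic ring, so that amino becomes (1-methyl-1H-pyrazol-4-yl)amino. Among the measured compounds shown here, no measured step covers this change, and the single step available is a loose yardstick at best. With compound 3 at 33 mL/min/kg as the starting point, a small upward move in this assay is expected, no larger than the modest 3.5-fold higher number from compound 2 to compound 3 (0.54 log units; beyond the scatter), and a result within the scatter remains quite possible. The expected size is a 1.2-fold higher number from compound 3 to compound 4 (0.08 log units; within the scatter). For compound 4 the estimate is 40 mL/min/kg, with an expected range of 18 mL/min/kg to 85 mL/min/kg.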

Compound 4, clearance: 65 mL/min/kg
Estimate against measurement, compound 4: 1.6-fold (0.21 log units) below; the range from low to high includes it.
By their numbers in this assay, from the lowest: compound 2; then compounds 1, 3 and 4 (each within the scatter of the next, the first and the last beyond it).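

Among these compounds, all earlier compounds carry the free amino group, so this nitrogen had no substituted example until now. In this assay, 1-methyl-1H-pyrazol-4-yl in place of hydrogen on this nitrogen gives a 2.0-fold higher number from compound 3 to compound 4 (0.29 log units; within the scatter) for this single change, so the added ring does not separate compound 4 from compound 3 on this read-out. Nothing available bears on the reason for this result.

Open, as far as these compounds go, is whether a smaller or differently built group on the same nitrogen, such as acetyl, methyl or phenyl, would give a step beyond the scatter. Also open, from the compounds shown here alone, is whether 1-methyl-1H-pyrazol-4-yl gives a similar step on compound 2, which has hydrogen in place of the chloro group and starts from a clearance of 9.5 mL/min/kg in the same assay.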